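Changing the Piperidine Nitrogen Substituent: What Compound 4 May Show

A few compounds are considered here, and "the series" means these few. Any claim that something is new, unique, unknown or untested is made for them only; others in the source may bear on it.

Measured so far in an assay on isolated protein for displacement of a labelled ligand from secreted frizzled-related protein 1 (Homo sapiens), read by fluorescence polarization, with a stated time of 30 min; a lower number here means a stronger inhibitor, a higher number a weaker inhibitor:
compound 1 `CN(C)c1ccc(C(=O)N2CCC(NS(=O)(=O)c3cc(S(=O)(=O)c4ccccc4)ccc3C(F)(F)F)CC2)cc1` gives 300 nM
compound 2 `O=S(=O)(NC1CCN(S(=O)(=O)c2ccccc2)CC1)c1cc(S(=O)(=O)c2ccccc2)ccc1C(F)(F)F` gives 130 nM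
compound 3 `CC(C)(O)CCN1CCC(NS(=O)(=O)c2cc(S(=O)(=O)c3ccccc3)ccc2C(F)(F)F)CC1` gives 200 nM

Compound 3 stands second highest of these three numbers, and its gap to each of compound 1 and compound 2 lies within the scatter. Compound 4 `O=C([C@@H]1CCNC1)N1CCC(NS(=O)(=O)c2cc(S(=O)(=O)c3ccccc3)ccc2C(F)(F)F)CC1` differs from compound 3 by (pyrrolidin-3-yl)carbonyl in place of 3-hydroxy-3-methylbutyl on an amine nitrogen in a ring. Three measured steps change a group on this same amine nitrogen in a ring: a 2.3-fold lower number from compound 1 to compound 2 (0.36 log units; beyond the scatter); a 1.5-fold lower number from compound 1 to compound 3 (0.18 log units; within the scatter); a 1.5-fold higher number from compound 2 to compound 3 (0.19 log units; within the scatter). Only one of them is beyond the scatter, and all are small. Compound 4 is therefore expected to show no change at the digits printed from compound 3 to compound 4 (within the scatter). In this assay compound 4 is estimated at 200 nM, with a range from 80 nM to 500 nM.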

Compound 4, half-maximal inhibitory concentration: 60 nM
For compound 4 the middle estimate is 3.3-fold (0.52 log units) above the measured one, outside the stated range (below it).
By their numbers in this assay, from the lowest: compound 4; then compounds 2, 3 and 1 (each within the scatter of the next, the first and the last beyond it).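

In this assay the group on the amine nitrogen in the ring can move the number further than the earlier groups suggested: (pyrrolidin-3-yl)carbonyl gives a 3.3-fold lower number from compound 3 to compound 4 (0.52 log units; beyond the scatter) against 3-hydroxy-3-methylbutyl, and a 2.2-fold lower number from compound 2 to compound 4 (0.34 log units; beyond the scatter) against phenylsulfonyl. The carbonyl alone does not settle it: a 5.0-fold lower number from compound 1 to compound 4 (0.70 log units; beyond the scatter) comes with pyrrolidin-3-yl in place of 4-(dimethylamino)phenyl on that carbonyl carbon.

As far as these compounds go, whether an open-chain amine or the mirror-image pyrrolidin-3-yl on the same carbonyl would do as well stays open. Nothing measured here explains the gain.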